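Benzyloxycarbonyl to tert-butoxycarbonyl on the shared core

This account rests on a few compounds, and the source may have more. Where it says the series, first, only, none or still open, it means among the compounds named here.

Measured in a toxicity assay on KB cells (Homo sapiens) for cytotoxicity, read by fluorescence, with a stated time of 3 days; on this read-out higher numbers stand for an effect only at larger amounts of compound and lower numbers for an effect already at smaller amounts:
- compound 1 `CCCCOC(=O)CNC(=O)[C@H](CSc1ccc([N+](=O)[O-])cc1[N+](=O)[O-])NC(=O)CC[C@H](NC(=O)CC(C)C)C(=O)OCCCC`: 59.6 uM
- compound 2 `CCCCOC(=O)CNC(=O)[C@H](CSc1ccc([N+](=O)[O-])cc1[N+](=O)[O-])NC(=O)CC[C@H](NC(=O)CCC(C)C)C(=O)OCCCC`: 84 uM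
- compound 3 `CCCCOC(=O)CNC(=O)[C@H](CSc1ccc([N+](=O)[O-])cc1[N+](=O)[O-])NC(=O)CC[C@H](NC(=O)OCc1ccccc1)C(=O)OCCCC`: 95.2 uM

Not yet measured: compound 4 `CCCCOC(=O)CNC(=O)[C@H](CSc1ccc([N+](=O)[O-])cc1[N+](=O)[O-])NC(=O)CC[C@H](NC(=O)OC(C)(C)C)C(=O)OCCCC`.

Compound 3, at 95.2 uM, cannot be separated from the other two compounds: the measured steps are a 1.6-fold higher number from compound 1 to compound 3 (0.20 log units; within the scatter) and a 1.1-fold higher number from compound 2 to compound 3 (0.05 log units; within the scatter). Compound 4 differs from compound 3 as follows: tert-butyl in place of benzyl on an oxygen next to a carbonyl group.

This exact exchange has not been measured in the series. The two steps above bear on it most closely, since they exchange benzyloxy with isobutyl and with isopentyl on a carbonyl carbon. The remaining step, a 1.4-fold higher number from compound 1 to compound 2 (0.15 log units; within the scatter), exchanges isopropyl for isobutyl. None of the three goes beyond the scatter, so no step beyond the scatter is expected in this assay. The expected step is a 1.1-fold lower number from compound 3 to compound 4 (0.05 log units; within the scatter). For compound 4 the estimate is 85 uM, with an expected range of 50 uM to 140 uM.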

Compound 4, concentration for half-maximal effect: 70.4 uM
For compound 4 the middle estimate is 1.2-fold (0.08 log units) above the measured one; measured number inside the range.
By their numbers in this assay, from the lowest: compounds 1, 4, 2 and 3 (each within the scatter of the next).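

In this assay the aromatic ring of the benzyl group can leave this position for the ring-free tert-butyl with only a small step (a 1.4-fold lower number from compound 3 to compound 4 (0.13 log units; within the scatter)). The (tert-butoxycarbonyl)amino compound also stays close to the two compounds carrying plain chains on the carbonyl carbon (a 1.2-fold lower number from compound 2 to compound 4 (0.08 log units; within the scatter); a 1.2-fold higher number from compound 1 to compound 4 (0.07 log units; within the scatter)), so all four groups tried here, with or without a ring or an oxygen next to the carbonyl group, sit within the scatter of one another. No measurement offers an explanation for this flat picture.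

Still open, on these data alone, is whether any group on this carbonyl carbon would give a step beyond the scatter, for example one ending in an amine or a carboxylic acid, or a longer chain. The same question stands for the butyl esters on the shared core, which are identical in all four compounds.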